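Swapping Amino for Methoxy on a Growth Inhibitor

A few compounds are considered here, and "the series" means these few. Any claim that something is new, unique, unknown or untested is made for them only; others in the source may bear on it.

Compound 1 `COc1cc(-c2cc(/C=C/C(=O)c3ccc(N)cc3)[nH]n2)cc(OC)c1OC` is one of three compounds tested in a functional assay on T47D cells (Homo sapiens) for inhibition, read by sulforhodamine B assay, with a stated time of 48 h (on this read-out higher numbers stand for weaker inhibition of growth and lower numbers for stronger inhibition of growth), where compound 1 gives 4300 nM. Compound 3 `COc1ccc(-c2cc(/C=C/C(=O)c3cc(OC)c(OC)c(OC)c3)[nH]n2)cc1OC` gives 3760 nM, a number within the scatter of that of compound 1. Compound 2 `COc1ccc(-c2cc(/C=C/C(=O)c3ccc(N)cc3)[nH]n2)cc1OC` differs from compound 1 only by hydrogen in place of methoxy on an aromatic carbon; in this assay compound 2 gives 26000 nM. The step of a 6.0-fold higher number from compound 1 to compound 2 (0.78 log units; beyond the scatter) is the only one measured so far. Compound 4 `COc1ccc(C(=O)/C=C/c2cc(-c3cc(OC)c(OC)c(OC)c3)n[nH]2)cc1` has not yet been measured; it differs from compound 1 in methoxy in place of amino on an aromatic carbon. None of the measured steps alters the amino group, so the single step shown does not bear directly on this change. Lacking such guidance, a step of no more than the scatter is expected, a 1.2-fold higher number from compound 1 to compound 4 (0.07 log units; within the scatter). Compound 4 is therefore estimated at 5000 nM, within 1500 nM to 16000 nM.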

Compound 4, concentration for total growth inhibition: 13000 nM
For compound 4 the middle estimate is 2.6-fold (0.41 log units) below the measured one, and the stated range covers the measured number.
By their numbers in this assay, from the lowest: compounds 3 and 1 (each within the scatter of the next); then compounds 4 and 2 (each within the scatter of the next).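

Methoxy in place of amino gives a 3.0-fold higher number from compound 1 to compound 4 (0.48 log units; beyond the scatter) in this assay, so the group on this ring, para to a large group, does affect growth inhibition, and the 4-aminophenyl form is the stronger of the two. Among these compounds, this is the first measured change at this position, and it shows that the two groups are not interchangeable here. Nothing shown explains the difference.

Going by these compounds, whether hydroxy, fluorine or dimethylamino at this place would match amino remains open. So does whether the same swap would have a similar effect on the core of compound 2.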